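The source may report more compounds than this note shows. Statements on the series, on what has been measured and on what is new or still open speak of the compounds shown alone.

Compound 2 `Cc1ccc(S(=O)(=O)N(C)CCN(C)C)cc1C#Cc1cc(Cl)ccc1OCC(=O)O` holds the higher of the two numbers recorded so far in an assay on CHO cells for displacement of a labelled ligand from prostaglandin D2 receptor 2 (Homo sapiens), read by scintillation counting (on this read-out higher numbers stand for weaker inhibition and lower numbers for stronger inhibition), where compound 2 gives 369 nM. Its only companion, compound 1 `CC(C)c1ccc(S(C)(=O)=O)cc1C#Cc1cc(C#N)ccc1OCC(=O)O`, gives 12 nM in this assay, a gap that lies well beyond the usual scatter; since the two compounds differ in several places at once, the numbers alone say nothing about which change carries the gap. Compound 3 `Cc1ccc(S(=O)(=O)N2CCCCC2C)cc1C#Cc1cc(Cl)ccc1OCC(=O)O` differs from compound 2 in one place on the sulfonyl sulfur, (2-methylpiperidin-1-yl in place of (2-(dimethylamino)ethyl)(methyl)amino on a sulfonyl sulfur). For the measured compounds named here, no measured pair shows the effect of such a change, so the expectation rests on the position of compound 2 only. The step from compound 2 to compound 3 in this assay is expected to be a 2.5-fold lower number from compound 2 to compound 3 (0.39 log units; beyond the scatter), a modest move toward a lower number. Compound 3 is estimated to give 150 nM in this assay, within a range from 40 nM to 600 nM.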

Compound 3, inhibition constant: 1.9 nM
Estimate against measurement, compound 3: 79-fold (1.90 log units) above; the measured number lies below the stated range.
By their numbers in this assay, from the lowest: compound 3; then compound 1; then compound 2.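

In this assay, the group on the sulfonyl sulfur turns out to weigh heavily: 2-methylpiperidin-1-yl in place of (2-(dimethylamino)ethyl)(methyl)amino gives a 190-fold lower number from compound 2 to compound 3 (2.29 log units; beyond the scatter), a large step. The heavy-atom count stays the same across this change, so the step comes with no change in that count; what differs is an open chain carrying a second nitrogen against a six-membered non-aromatic ring with a single hetero atom. Nothing available here explains the size of this step. The compounds shown leave open whether the ring itself or its 2-methyl group carries the step, which plain piperidin-1-yl or morpholin-4-yl on the same sulfur would help to separate. They also leave open whether 2-methylpiperidin-1-yl would act the same way alongside the other groups of compound 1.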